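The source may report more compounds than this note shows. Statements on the series, on what has been measured and on what is new or still open speak of the compounds shown alone.

Measured so far in an ADME assay on MRC5 cells (Homo sapiens) for cytotoxicity, read by fluorescence, with a stated time of 72 h; on this read-out higher numbers stand for weaker inhibition and lower numbers for stronger inhibition:
- Compound 1 `CC1(COCc2ccc(OC(F)(F)F)cc2)Cn2cc([N+](=O)[O-])nc2O1`: 60000 nM
- Compound 2 `O=[N+]([O-])c1cn2c(n1)OC(COc1ccc(-c3ccc(F)cc3)nc1)C2`: > 64000 nM

Compound 1 gives a measured number, 60000 nM. Compound 2 gives no number: its > 64000 nM is a limit of the assay. This is the limit of > 64000 nM in this assay, at which 1 of the 2 values shown sits.

Compound 3 `O=[N+]([O-])c1cn2c(n1)O[C@@H](COc1ccc(-c3ccc(F)cc3)nc1)C2` is the next to be read. The change from compound 2 is this: the two compounds have the same atoms and bonds; at least one stereo element is drawn with a configuration in one of them and without one in the other: 1 of 1 stereo elements differ; a stereocentre at a saturated ring carbon is drawn without a configuration in compound 2 and R in compound 3. The same atoms and bonds remain, and a stereocentre at a saturated ring carbon is drawn without a configuration in compound 2 and R in compound 3. Within the data shown here, no measured pair here shows what such a change does in this assay, so no shift beyond the usual scatter is expected, in either direction. The estimated step of an at least 1.0-fold lower number from compound 2 to compound 3 (0.02 log units; that floor lies within the scatter) is therefore small. For compound 3 the expected value is 60000 nM, with an estimated range from 30000 nM to 64000 nM.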

Compound 3, half-maximal inhibitory concentration in the MRC5 assay: > 64000 nM
Compound 3: a limit, no number; the forecaster's own chance of this, stated with the estimate: 70%; at least 1.0-fold (0.02 log units) between middle value and limit.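

In the MRC5 assay compound 2 gives > 64000 nM as a limit and not a number. In the MRC5 assay compound 3 gives > 64000 nM as a limit and not a number. No step from compound 2 to compound 3 can be read in the MRC5 assay because both compounds give a limit and not a number: the limit of > 64000 nM in the MRC5 assay, at which 2 of the 3 values shown sit.

The compounds shown leave open whether the R configuration drawn in compound 3 shifts the read-out of the MRC5 assay in either direction.

In a physicochemical assay for solubility, read by HPLC, measured as kinetic solubility, at 20 degrees C, at pH 7 (a higher number here means a more soluble compound, a lower number a less soluble compound), compound 2 gives 1.3 ug/mL and compound 3 gives 1.1 ug/mL as measured numbers. In the physicochemical assay the step reads a 1.2-fold lower number from compound 2 to compound 3 (0.07 log units; within the scatter) and so the two values stand within the scatter of each other.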